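Ring expansion on the aminomethyl side chain of compound 1

The source may hold more compounds than are shown below. What is called first, only, known or untested is meant among the compounds shown, and "the series" means these compounds.

Measured so far:
compound 1 `FC(F)(F)c1cc(NC[C@H]2CCCN2)c2cn[nH]c2c1` — 34%
compound 2 `O=[N+]([O-])c1cc(OCc2ccccc2)ccc1CNc1cc(C(F)(F)F)cc2[nH]ncc12` — 10%
compound 3 `NCCn1ncc2c(NCc3ccccc3[N+](=O)[O-])cc(C(F)(F)F)cc21` — 9%

In an assay for inhibition of Indoleamine 2,3-dioxygenase 1 (Homo sapiens), with stated times of 10 min and 60 min, tested at 10 uM (a lower number here means a weaker effect, a higher number a stronger effect of the compound at the concentration tested), compound 1 gives 34%, the highest of the three numbers; the gaps down to compound 2 and to compound 3 both lie beyond the scatter. Among the compounds with values here, no pair among the measured compounds differs in one place only, so no single-point step is available as a guide. Compound 4 `FC(F)(F)c1cc(NC[C@@H]2CCCCN2)c2cn[nH]c2c1` differs from compound 1 by piperidin-2-yl in place of pyrrolidin-2-yl on a saturated chain carbon bound to a nitrogen on an aromatic ring. Nothing measured speaks for or against this change, so no step beyond the scatter is expected in this assay; the step of a number 4 percentage points lower from compound 1 to compound 4 (within the scatter) is the expectation. Compound 4 is thus estimated at 30%, with a range from 10% to 55%.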

Compound 4, a percentage reported as inhibition, at one concentration (the size of the read-out at that concentration, not a potency): 32%
The estimate for compound 4 lay 2 percentage points below the measured number; the range from low to high includes it.
By their numbers in this assay, from the lowest: compounds 3 and 2 (each within the scatter of the next); then compounds 4 and 1 (each within the scatter of the next).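

In this assay, piperidin-2-yl in place of pyrrolidin-2-yl on a saturated chain carbon bound to a nitrogen on an aromatic ring gives a number 2 percentage points lower from compound 1 to compound 4 (within the scatter). This first single-place comparison in the series shows that the six-membered non-aromatic ring can stand in for the five-membered one at this position without a step beyond the scatter. No available evidence bears on the reason for this result.

On these data alone, it remains open whether the ring nitrogen is needed, which a cyclohexyl group in its place would address. As far as these compounds go, it is also open whether a larger azepan-2-yl ring is tolerated.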